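Nitro in place of ethoxy: an expected step

A few compounds are considered here, and "the series" means these few. Any claim that something is new, unique, unknown or untested is made for them only; others in the source may bear on it.

Measured so far in a functional assay on HeLa cells (Homo sapiens) for inhibition, with a stated time of 72 h; a lower number here means a stronger inhibitor, a higher number a weaker inhibitor:
Compound 1 `O=c1[nH]c(=O)n([C@H]2C[C@H](O)[C@@H](CO)O2)cc1COc1cccc(Br)c1` gives 15000 nM
Compound 2 `CCOc1ccc(OCc2cn([C@H]3C[C@H](O)[C@@H](CO)O3)c(=O)[nH]c2=O)cc1` gives 250000 nM

Of these two, compound 2 has the highest number and so marks the weak end of what has been measured. Compound 3 `O=c1[nH]c(=O)n([C@H]2C[C@H](O)[C@@H](CO)O2)cc1COc1ccc([N+](=O)[O-])cc1` has not yet been measured. It departs from compound 2 in one place, with nitro in place of ethoxy on an aromatic carbon, para to a large group: nitro in place of ethoxy on an aromatic carbon.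

Within the data shown here, only one measured step bears on this change. That step, a 17-fold higher number from compound 1 to compound 2 (1.22 log units; beyond the scatter), put 4-ethoxyphenyl in place of 3-bromophenyl and shows that this part of the structure can shift the number widely. Among the measured compounds shown here, no measured compound carries nitro, so the direction remains tentative. A smaller move towards lower numbers seems likely in this assay, and the expected step is a 5.0-fold lower number from compound 2 to compound 3 (0.70 log units; beyond the scatter) here. For compound 3 the estimated value is 50000 nM, with an expected range from 10000 nM to 250000 nM.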

Compound 3, half-maximal inhibitory concentration: 250000 nM
Compound 3: middle estimate off by 5.0-fold (0.70 log units), on the low side; the range from low to high includes it.
By their numbers in this assay, from the lowest: compound 1; then compounds 2 and 3 (each within the scatter of the next).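

In this assay the exchange of ethoxy for nitro on the aromatic carbon, para to a large group, gives no change at the digits printed from compound 2 to compound 3 (within the scatter) and so, unlike the earlier exchange of aryl groups, leaves the number where it stood. Set against the 3-bromophenyl compound, the 4-nitrophenyl group gives a 17-fold higher number from compound 1 to compound 3 (1.22 log units; beyond the scatter) and repeats the size of the earlier step, so both 4-substituted compounds shown stand well on the weak side of compound 1. Nothing available explains why ethoxy and nitro read alike here.

The compounds shown do not settle whether the lower number of compound 1 goes with the bromine itself or with where it sits on the ring. From the compounds shown here alone, how an amine or a carboxylic acid would read in place of nitro also remains open.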